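This account rests on a few compounds, and the source may have more. Where it says the series, first, only, none or still open, it means among the compounds named here.

Measured compounds:
compound 1 `Cc1nc(-c2ccccc2)sc1C(=O)CSc1nc(-c2ccccc2)c(C#N)c(=O)[nH]1`, 93500 nM
compound 2 `Cc1nc(-c2ccc(Cl)cc2)sc1C(=O)CSc1nc(-c2ccccc2)c(C#N)c(=O)[nH]1`, "not determined" (no result reported)
compound 3 `COc1cccc(-c2nc(SCC(=O)c3sc(-c4ccc(Cl)cc4)nc3C)[nH]c(=O)c2C#N)c1`, 77900 nM

In an ADME assay on HEK293 cells (Homo sapiens) for cytotoxicity, read by MTT assay, with a stated time of 48 h (on this read-out higher numbers stand for weaker inhibition and lower numbers for stronger inhibition), compound 1 gives 93500 nM, the higher of the two numbers available. Compound 3 gives 77900 nM in this assay, and its difference from compound 1 lies within the usual scatter, so the two cannot be ranked against each other. For compound 2 this assay records "not determined" (no result reported), so no number is available for it.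

Compound 4 `Cc1nc(-c2ccccc2)sc1C(=O)CSc1nc(-c2ccc(Cl)c(Cl)c2)c(C#N)c(=O)[nH]1` has not been measured. It differs from compound 1 in one place: 3,4-dichlorophenyl in place of phenyl on an aromatic carbon. Among the compounds with values here, no step between two measured compounds isolates this change, so there is nothing to scale it against. The two measured values sit close together at the weak end of the read-out. The step of a 1.3-fold lower number from compound 1 to compound 4 (0.13 log units; within the scatter) is expected to be small, perhaps towards a slightly lower number, and may not exceed the scatter. Compound 4 is therefore estimated at 70000 nM in this assay, with a range from 30000 nM to 150000 nM.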

Compound 4, half-maximal inhibitory concentration: 85100 nM
Compound 4: middle estimate off by 1.2-fold (0.08 log units), on the low side; the measured number falls inside the stated range.
By their numbers in this assay, from the lowest: compounds 3, 4 and 1 (each within the scatter of the next).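

In this assay, 3,4-dichlorophenyl in place of phenyl, on the aromatic carbon ortho to a cyano group, gives a 1.1-fold lower number from compound 1 to compound 4 (0.04 log units; within the scatter). Within the data shown here, this is the first step that isolates a single place, and it shows that this position accepts the larger 3,4-dichlorophenyl group with a read-out that cannot be told apart from that of the phenyl compound. Nothing available explains this outcome.

The compounds shown leave open whether this tolerance extends to groups of another kind at this position, such as an amine, a carboxylic acid or a longer chain. They also leave open whether any group here can give a number clearly apart from that of compound 1 in this assay.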